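Acyclic methanesulfonamide chain replacing the piperidinyl imidazolidinone

The compounds below may be only part of what the source reports. "The series", "measured", "known", "first", "only" and "open" are said of these compounds alone.

Compound 3 `Cc1nc(N2CCC(N3CCNC3=O)CC2)nc2ccc(NC(=O)/C=C/c3ccc(OC(F)(F)F)cc3)cc12` gives 31 nM in a functional assay on CHO-K1 cells for antagonist activity at melanin-concentrating hormone receptor 1 (Homo sapiens), read by inositol phosphate accumulation, with stated times of 10 min and 45 min; a higher number here means a weaker inhibitor, a lower number a stronger inhibitor. Compound 1 `Cc1nc(N2CCC(N3CCOC3=O)CC2)nc2ccc(NC(=O)/C=C/c3ccc(OC(F)(F)F)cc3)cc12` gives 31 nM in this assay, and compound 2 `Cc1nc(NCCNC(=O)C2CC2)nc2ccc(NC(=O)/C=C/c3ccc(OC(F)(F)F)cc3)cc12` gives 23 nM. With no change at the digits printed from compound 1 to compound 3 (within the scatter) and a 1.3-fold higher number from compound 2 to compound 3 (0.13 log units; within the scatter), compound 3 stands level with compound 1 at the digits shown, the two together the highest of the three numbers, and all three numbers lie within the scatter of one another.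

Compound 4 `Cc1nc(NCCCNS(C)(=O)=O)nc2ccc(NC(=O)/C=C/c3ccc(OC(F)(F)F)cc3)cc12` differs from compound 3 in one place: (3-(methanesulfonamido)propyl)amino in place of 4-(2-oxoimidazolidin-1-yl)piperidin-1-yl on an aromatic carbon. The two measured steps that bear on this change are a 1.3-fold higher number from compound 2 to compound 3 (0.13 log units; within the scatter), where a ring-based group took the place of an acyclic (2-((cyclopropylcarbonyl)amino)ethyl)amino chain, and a 1.3-fold lower number from compound 1 to compound 2 (0.13 log units; within the scatter), the reverse kind of exchange; neither left the scatter. Exchanging the ring-based group of compound 3 for an acyclic (3-(methanesulfonamido)propyl)amino chain is therefore expected to give no step beyond the scatter, with a 1.1-fold lower number from compound 3 to compound 4 (0.06 log units; within the scatter) as the expected step. For compound 4 the estimated value in this assay is 27 nM, within the range 10 nM to 75 nM.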

Compound 4, half-maximal inhibitory concentration: 32 nM
Beside the measured number, compound 4's estimate is 1.2-fold (0.07 log units) below it, and the stated range covers the measured number.
By their numbers in this assay, from the lowest: compounds 2, 1, 3 and 4 (each within the scatter of the next).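

On the aromatic carbon between two ring nitrogen atoms, the acyclic (3-(methanesulfonamido)propyl)amino chain, which has no ring, can stand in for either ring-based group in this assay (a 1.0-fold higher number from compound 3 to compound 4 (0.01 log units; within the scatter); a 1.0-fold higher number from compound 1 to compound 4 (0.01 log units; within the scatter)). Within the acyclic chains, (methanesulfonamido)methyl in place of (cyclopropylcarbonyl)amino also leaves the number within the scatter (a 1.4-fold higher number from compound 2 to compound 4 (0.14 log units; within the scatter)), so a carbonyl in this substituent, present in compounds 1, 2 and 3, is not needed to hold the number in this range. Nothing shown gives a reason for this flat response.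

Still open, on these data alone, is whether any group at this position moves the number beyond the scatter. A primary amine or a carboxylic acid at the chain end, or a longer chain, would test this.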